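Swapping the Amide Aryl Group of Compound 2

A few compounds are considered here, and "the series" means these few. Any claim that something is new, unique, unknown or untested is made for them only; others in the source may bear on it.

Of the compounds shown here, two of one shared core have been tested in a functional assay on the whole organism for inhibition, with Mus musculus as the target, at a dose of 1 mg/kg by the oral route; on this read-out lower numbers stand for less inhibition and higher numbers for more inhibition at the one dose given (going by the name of the read-out). Compound 1 `CCN(C(=O)c1c(O)c2c(C(F)(F)F)cccc2n(C)c1=O)c1ccccc1` gives 80%. Compound 2 `COc1cccc2c1c(O)c(C(=O)N(C)c1cc(F)ccc1F)c(=O)n2C` gives 90% in this assay, a number within the usual scatter of the number for compound 1, so the two cannot be ordered. Compound 3 `COc1ccc(N(C)C(=O)c2c(O)c3c(OC)cccc3n(C)c2=O)cc1` is not yet measured; it differs from compound 2 by 4-methoxyphenyl in place of 2,5-difluorophenyl on an amide-type nitrogen. For the measured compounds named here, no measured pair shows a step of this kind, so the step of a number 15 percentage points lower from compound 2 to compound 3 (beyond the scatter) is an expectation only, and a small downward change, or none beyond the scatter, is anticipated. For compound 3 the estimated inhibition in this assay is 75%, expected to fall between 45% and 95%.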

Compound 3, a percentage reported as inhibition, in the whole organism at one dose (the size of the read-out at that dose, not a potency): 84%
For compound 3 the middle estimate is 9 percentage points below the measured one; measured number inside the range.
By their numbers in this assay, from the lowest: compounds 1, 3 and 2 (each within the scatter of the next).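

Putting 4-methoxyphenyl in place of 2,5-difluorophenyl on the amide-type nitrogen gives a number 6 percentage points lower from compound 2 to compound 3 (within the scatter) in this assay. For the compounds shown here, this is the first single-place comparison, and it shows that this aryl group can lose both fluorines and gain a methoxy group with no change that can be told from the scatter. From the compounds shown here alone, whether a pyridine ring, a cyclohexyl group or a chain ending in an amine at this place would behave the same remains open. No measurement at hand offers an explanation for this result.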